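The source may report more compounds than this note shows. Statements on the series, on what has been measured and on what is new or still open speak of the compounds shown alone.

Working notes on the series. In a functional assay on MCF7 cells (Homo sapiens) for antiproliferative activity, read by CellTiter-Glo, with a stated time of 5 days (on this read-out higher numbers stand for weaker inhibition and lower numbers for stronger inhibition), compound 1 `CC1=C(c2cccc(C#N)c2)C(c2ccc(OC[C@H](C)N3CC[C@@H](C)C3)cc2)Oc2ccc(O)cc21` gives 2.6 nM, the highest of the three numbers recorded. Within the data shown here, compound 2 `CC1=C(c2cccc(O)c2)C(c2ccc(OC[C@H](C)N3CC[C@H](C)C3)cc2)Oc2ccc(O)cc21` gives 0.2 nM and compound 3 `CC1=C(c2cccc(O)c2)C(c2ccc(OC[C@H](C)N3CCCCC3)cc2)Oc2ccc(O)cc21` gives 0.1 nM; the one single-point step, a 2.0-fold lower number from compound 2 to compound 3 (0.30 log units; within the scatter), concerns the amine and not the aryl group. Compound 4 `CC1=C(c2ccc(F)cc2)C(c2ccc(OC[C@H](C)N3CC[C@@H](C)C3)cc2)Oc2ccc(O)cc21` is reached from compound 1 by 4-fluorophenyl in place of 3-cyanophenyl on a double-bonded ring carbon. Among the measured compounds shown here, no measured step changes that aryl group alone; compound 2 differs from compound 1 in more than one place, so its lower number cannot be assigned to the aryl change. In this assay compound 4 is therefore expected near compound 1, with the step of a 1.9-fold higher number from compound 1 to compound 4 (0.28 log units; within the scatter) treated as uncertain. Compound 4 is estimated at 5 nM, with a range of 1.5 nM to 20 nM.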

Compound 4, half-maximal inhibitory concentration: 0.4 nM
For compound 4 the middle estimate is 13-fold (1.10 log units) above the measured one; measured number below the stated range.
By their numbers in this assay, from the lowest: compounds 3, 2 and 4 (each within the scatter of the next, the first and the last beyond it); then compound 1.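

Among these compounds, with the 3-methylpyrrolidin-1-yl amine held fixed, this assay gives the only direct reading of the aryl group on this double-bonded ring carbon (a 6.5-fold lower number from compound 1 to compound 4 (0.81 log units; beyond the scatter)). Exchanging 3-cyanophenyl for 4-fluorophenyl alone therefore moves the number beyond the scatter, and the change is tolerated here with a lower number. Nothing on hand accounts for the size of this step.

A 4-cyanophenyl or 3-fluorophenyl group at this carbon would separate the effect of the substituent from that of its ring position. On these data alone, whether the step carries over to the piperidin-1-yl amine remains open.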